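From 2-fluorophenyl to 3,4-difluorophenyl on a shared core

The compounds below may be only part of what the source reports. "The series", "measured", "known", "first", "only" and "open" are said of these compounds alone.

Measured in a functional assay on Bel7402/5-FU cells (Homo sapiens) for antiproliferative activity, read by MTT assay, with a stated time of 72 h (on this read-out higher numbers stand for weaker inhibition and lower numbers for stronger inhibition), the two compounds read as follows:
Compound 1 `C=C1C(=O)O[C@H]2[C@H]1CC/C(COC(=O)Cn1cc(F)c(=O)n(Cc3ccc(F)cc3)c1=O)=C\CC[C@@]1(C)O[C@@H]21` gives 1140 nM in this test
Compound 2 `C=C1C(=O)O[C@H]2[C@H]1CC/C(COC(=O)Cn1cc(F)c(=O)n(Cc3ccccc3F)c1=O)=C\CC[C@@]1(C)O[C@@H]21` gives 3830 nM in this test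

Of these two, compound 2 holds the higher number at 3830 nM and so shows the weaker inhibition. The next compound is compound 3 `C=C1C(=O)O[C@H]2[C@H]1CC/C(COC(=O)Cn1cc(F)c(=O)n(Cc3ccc(F)c(F)c3)c1=O)=C\CC[C@@]1(C)O[C@@H]21` which shares the core of compound 1. The change 3,4-difluorophenyl in place of 2-fluorophenyl on a saturated chain carbon bound to an aromatic nitrogen puts 3,4-difluorophenyl in place of 2-fluorophenyl on a saturated chain carbon bound to an aromatic nitrogen.

Only a 3.4-fold higher number from compound 1 to compound 2 (0.53 log units; beyond the scatter) bears on this change, a modest step beyond the scatter that brought in the 2-fluorophenyl group which compound 3 gives up. For the measured compounds named here, no measured compound carries 3,4-difluorophenyl, and a single step shows no pattern, so the forecast is uncertain. A step of similar or somewhat smaller size towards a lower number is expected in this assay for this change. The estimate means a 2.4-fold lower number from compound 2 to compound 3 (0.38 log units; beyond the scatter) as the expected step. Compound 3 is estimated at 1600 nM with 650 nM to 3900 nM as the expected range.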

Compound 3, half-maximal inhibitory concentration: 4480 nM
Estimate against measurement, compound 3: 2.8-fold (0.45 log units) below; measured number above the stated range.
By their numbers in this assay, from the lowest: compound 1; then compounds 2 and 3 (each within the scatter of the next).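

In this assay, the 3,4-difluorophenyl group of compound 3 does not bring back the level of compound 1: the exchange for 2-fluorophenyl reads as a 1.2-fold higher number from compound 2 to compound 3 (0.07 log units; within the scatter), so on a saturated chain carbon bound to an aromatic nitrogen these two groups cannot be told apart. Fluoro in place of hydrogen on an aromatic carbon of the 4-fluorophenyl group, by contrast, weakens inhibition, with a 3.9-fold higher number from compound 1 to compound 3 (0.59 log units; beyond the scatter), which leaves compound 1 standing apart from compound 2 and compound 3, the only one of the three with its number beyond the scatter of the others. Nothing given here accounts for this difference between the groups.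

The compounds shown leave open whether the edge of compound 1 depends on its fluorine at all, since a plain phenyl group on this carbon would be needed to tell. Going by these compounds, how a chlorophenyl or methoxyphenyl group would read at this position, or a longer chain in place of the single carbon carrying the ring, also remains open.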